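Methylation of the tetrazole ring nitrogen in the chromone carboxamides

A few compounds are considered here, and "the series" means these few. Any claim that something is new, unique, unknown or untested is made for them only; others in the source may bear on it.

Compound 2 `O=C(Nc1nnn[nH]1)c1cc(=O)c2ccccc2o1` holds the lowest number among the three measured compounds in a functional assay on cells (Mast cell, Rattus norvegicus) for inhibition, with a stated time of 15 min (a higher number here means that more compound is needed for the effect, a lower number that less compound is needed), giving 0.08 ug/mL. Compound 3 `CNc1c(C(=O)Nc2nnn[nH]2)oc2ccccc2c1=O` gives 0.4 ug/mL, and compound 1 `O=C(Nc1nc[nH]n1)c1cc(=O)c2ccccc2o1` gives 5 ug/mL. The step of a 63-fold lower number from compound 1 to compound 2 (1.80 log units; beyond the scatter) is large; the step of a 5.0-fold higher number from compound 2 to compound 3 (0.70 log units; beyond the scatter) is modest.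

Compound 4 `Cn1nnnc1NC(=O)c1cc(=O)c2ccccc2o1` differs from compound 2 by methyl in place of hydrogen on an aromatic nitrogen. The change sits on the five-membered aromatic ring with 4 nitrogen, the same ring that the step from compound 1 to compound 2 exchanged, and that exchange moved the number far. For the measured compounds named here, no measured step alters this ring while keeping its atoms, and no measured compound carries a methyl on an aromatic nitrogen; the step from compound 2 to compound 3 concerns a different place and gives little guidance. Given that the ring identity mattered so much in a 63-fold lower number from compound 1 to compound 2 (1.80 log units; beyond the scatter), the loss of the ring hydrogen is expected to cost potency, and an upward step a 25-fold higher number from compound 2 to compound 4 (1.40 log units; beyond the scatter) is estimated. Compound 4 is therefore expected to give 2 ug/mL, within a range from 0.3 ug/mL to 15 ug/mL.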

Compound 4, concentration for half-maximal effect: > 18 ug/mL
Compound 4 was reported as a limit; the forecaster's own chance of this, stated with the estimate: 15%; middle value at least 9.0-fold (0.95 log units) away from the limit.
By their numbers in this assay, from the lowest: compound 2; then compound 3; then compound 1. At a limit, above all of these: compound 4.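

Compound 4 is reported only as a limit in this assay: the limit of > 18 ug/mL in this assay, at which 1 of the 4 values shown sits. Putting 1-methyl-1H-tetrazol-5-yl in place of 1H-tetrazol-5-yl gives an at least 220-fold higher number from compound 2 to compound 4 (2.35 log units; beyond the scatter), so this aromatic nitrogen is sensitive to a single methyl even when the ring atoms stay the same. Exchanging 1H-1,2,4-triazol-3-yl for 1-methyl-1H-tetrazol-5-yl gives an at least 3.6-fold higher number from compound 1 to compound 4 (0.55 log units; beyond the scatter), which places the methylated ring behind both unmethylated rings shown.

The compounds shown do not separate the effect of losing the ring hydrogen from that of adding the methyl. They also leave open how an ethyl group or a longer chain on this nitrogen would read, and whether a carboxylic acid in place of the ring would retain activity.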